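Capping the chain amine of compound 2 with tert-butoxycarbonyl

The source may report more compounds than this note shows. Statements on the series, on what has been measured and on what is new or still open speak of the compounds shown alone.

Compound 2, with structure `NCCCCCN1C(Nc2ccc(-c3ccccc3)cc2)=Nc2ccccc2C1CC(=O)NCc1ccccc1`, was tested in an assay on HEK293 cells for inhibition of Voltage-dependent T-type calcium channel subunit alpha-1G (Homo sapiens); on this read-out lower numbers stand for stronger inhibition and higher numbers for weaker inhibition. In this assay, among the measured compounds shown here, compound 2 gives 140 nM, the higher of the two numbers measured so far, while its nearest neighbour compound 1, with structure `NCCCCCNC1=Nc2ccccc2C(CC(=O)NCc2ccccc2)N1c1ccc(-c2ccccc2)cc1`, gives 130 nM; the two values lie within the scatter of each other, so no order between them can be claimed. Compound 3, with structure `CC(C)(C)OC(=O)NCCCCCN1C(Nc2ccc(-c3ccccc3)cc2)=Nc2ccccc2C1CC(=O)NCc1ccccc1`, has not been measured. It differs from compound 2 by tert-butoxycarbonyl in place of hydrogen on an amine nitrogen. For the measured compounds named here, no pair of measured compounds shows what this kind of change does here, so the expectation rests on compound 2 alone. The step from compound 2 to compound 3 is estimated as a 2.9-fold higher number from compound 2 to compound 3 (0.46 log units; beyond the scatter), a modest rise in the number, with wide uncertainty in either direction. Compound 3 is therefore expected to give about 400 nM, in a range from 100 nM to 2000 nM.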

Compound 3, half-maximal inhibitory concentration: 170 nM
Compound 3: middle estimate off by 2.4-fold (0.37 log units), on the high side; measured number inside the range.
By their numbers in this assay, from the lowest: compounds 1, 2 and 3 (each within the scatter of the next).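

In this assay, tert-butoxycarbonyl in place of hydrogen on the amine nitrogen of the chain amounts to a 1.2-fold higher number from compound 2 to compound 3 (0.08 log units; within the scatter). Among the compounds shown here, this is the first reading of any change at this nitrogen, and it shows that a free amine there is not required for a number of this size, since a group of 7 heavy atoms with no net charge leaves compound 3 within the scatter of compound 2. Nothing available explains why the change has so little effect. From the compounds shown here alone, it remains open whether a smaller acetyl cap, a carboxylic acid in place of the amine, or a longer chain would also leave the number unmoved. Going by these compounds, it is equally open whether the same tert-butoxycarbonyl cap on compound 1 would behave in this way.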